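Cytotoxicity Limits Across Three Measured Analogues and One Untested

The compounds below may be only part of what the source reports. "The series", "measured", "known", "first", "only" and "open" are said of these compounds alone.

Measured compounds:
- Compound 1 `COc1cccc(NC(=O)c2c(NCCO)cc(-c3ccc(Br)cc3)oc2=O)c1`: in an ADME assay on Huh-7 cells (Homo sapiens) for cytotoxicity, with a stated time of 3 days (a lower number here means that less compound is tolerated, a higher number that more compound is tolerated), compound 1 gives > 20000 nM, which is a limit of the assay rather than a number.
- Compound 2 `CCOc1ccccc1NC(=O)c1c(NCCO)cc(-c2ccc(Br)cc2)oc1=O`: in this assay compound 2 gives > 20000 nM, again only a limit.
- Compound 3 `COc1cccc(NC(=O)c2c(NCCO)cc(-c3cccs3)oc2=O)c1`: in this assay compound 3 gives > 20000 nM, also a limit.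

Compound 2 is made from compound 1 by 2-ethoxyphenyl in place of 3-methoxyphenyl on an amide-type nitrogen. Because both values are limits, the step that the two limits leave unreadable from compound 1 to compound 2 cannot be read. Compound 3 differs from compound 1 in its core by thiophen-2-yl in place of 4-bromophenyl on an aromatic carbon, and the step that the two limits leave unreadable from compound 1 to compound 3 is likewise unreadable.

Compound 4 `CCOc1ccccc1NC(=O)c1c(NCCO)cc(-c2cccs2)oc1=O` has not been measured. It stands to compound 3 as compound 2 stands to compound 1: 2-ethoxyphenyl in place of 3-methoxyphenyl on an amide-type nitrogen. The surroundings of the changed group are described in the same words for both pairs, so this is the same change.

The expected step that the limit leaves unreadable from compound 3 to compound 4 rests on (the limit of > 20000 nM in this assay, at which 3 of the 3 values shown sit), since compound 1 and compound 2, which differ by this very change, both sit at that limit. Compound 4 is therefore expected to show 30000 nM in this assay, most likely reported again as a limit.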

Compound 4, half-maximal cytotoxic concentration: 10000 nM
The estimate for compound 4 lay 3.0-fold (0.48 log units) above the measured number, and the stated range ends above it.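

In this assay compound 4 gives 10000 nM, a real number: 2-ethoxyphenyl in place of 3-methoxyphenyl on the amide-type nitrogen gives an at least 2.0-fold lower number from compound 3 to compound 4 (0.30 log units; that floor lies within the scatter), and thiophen-2-yl in place of 4-bromophenyl gives an at least 2.0-fold lower number from compound 2 to compound 4 (0.30 log units; that floor lies within the scatter). Each of these steps starts from a limit, so only its smallest possible size is known, and that size does not go beyond the usual scatter, which means neither step is shown to be a real drop. The steps between two limits cannot be read, so the size of the same change on the core of compound 1 stays unknown, and the data neither show that the change carries over from one core to the other nor show that it fails to: the limit of > 20000 nM in this assay, at which 3 of the 4 values shown sit.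

From the compounds shown here alone, it remains open how a longer chain in place of the ethoxy group, or a carboxylic acid on the same phenyl ring, would fare in this assay. Going by these compounds, the true size of the gap between compound 3 and compound 4 also remains open.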